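A small amide in place of the cyanophenyl arm

The compounds below may be only part of what the source reports. "The series", "measured", "known", "first", "only" and "open" are said of these compounds alone.

The series shares a core in which a ketone chain ending in a phenyl group sits on a five-membered aromatic ring. Compound 1, `Nc1ccccc1-c1cnc(C(=O)CCCCCCc2ccccc2)o1`, carries a 2-aminophenyl group on that ring and in an assay (Rattus norvegicus) for inhibition of Fatty-acid amide hydrolase 1 (Homo sapiens) (a higher number here means a weaker inhibitor, a lower number a stronger inhibitor), compound 1 gives 750 nM. Compound 2, `N#Cc1ccc(-c2cnc(C(=O)CCCCCCc3ccccc3)o2)cc1`, carries a 4-cyanophenyl group instead, and in this assay compound 2 gives 40 nM. Within the data shown here, the one step measured so far, a 19-fold lower number from compound 1 to compound 2 (1.27 log units; beyond the scatter), is large, and compound 2 stands with the lowest of the two numbers, its only neighbour being compound 1 with the higher value.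

Compound 3, `CNC(=O)c1cnc(C(=O)CCCCCCc2ccccc2)o1`, has not been measured yet. It differs from compound 2 in one place: methylcarbamoyl in place of 4-cyanophenyl on an aromatic carbon. Among the measured compounds shown here, no measured step bears directly on this change; the step from compound 1 to compound 2 only shows that the group at this aromatic carbon can shift the number a great deal. Compound 3 is therefore expected to lose ground relative to compound 2, by a step of about a 6.3-fold higher number from compound 2 to compound 3 (0.80 log units; beyond the scatter). The estimate for compound 3 in this assay is 250 nM, within a range from 50 nM to 1500 nM.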

Compound 3, inhibition constant: 7 nM
Compound 3: middle estimate off by 36-fold (1.55 log units), on the high side; measured number below the stated range.
By their numbers in this assay, from the lowest: compound 3; then compound 2; then compound 1.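

The change from 4-cyanophenyl to methylcarbamoyl gives a 5.7-fold lower number from compound 2 to compound 3 (0.76 log units; beyond the scatter) in this assay and so shows that a six-membered aromatic ring on this carbon is not needed for a low number: a group of 4 heavy atoms with no ring goes lower than one of 8 heavy atoms. Set against 2-aminophenyl, the same amide gives a 110-fold lower number from compound 1 to compound 3 (2.03 log units; beyond the scatter) in this assay and this widens the span already seen at this position, with the lowest of the three numbers now held by the only compound that has no aromatic ring on this carbon. Nothing available here accounts for the low number of the amide.

Going by these compounds, how a primary carboxamide, a dimethylcarbamoyl group, a longer alkyl group on the amide nitrogen or a carboxylic acid on this carbon would compare with methylcarbamoyl remains open, and so does the part played by the amide hydrogen. Also open, on these data alone, is whether the drop seen with methylcarbamoyl would carry over to a shorter or longer chain on the ketone, since all three compounds share the same chain.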